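This account rests on a few compounds, and the source may have more. Where it says the series, first, only, none or still open, it means among the compounds named here.

For the measured compounds named here, compound 2 `CN1CCN(c2cccc3c2C[C@H](CN(C)[C@H]2CCCc4cccnc42)NC3)CC1` stands, in a functional assay on CCRF-CEM cells for antagonist activity at C-X-C chemokine receptor type 4 (Homo sapiens), read by calcium flux, with stated times of 25 min and 90 s (a higher number here means a weaker inhibitor, a lower number a stronger inhibitor), at 29.6 nM, the second highest of the three numbers measured so far: compound 1 `C[C@@H]1CN(c2cccc3c2C[C@H](CN(C)[C@H]2CCCc4cccnc42)NC3)C[C@H](C)N1` gives 61 nM and compound 3 `CCN1CCN(c2cccc3c2C[C@H](CN(C)[C@H]2CCCc4cccnc42)NC3)CC1` gives 13.8 nM, so that a 2.1-fold lower number from compound 1 to compound 2 (0.31 log units; beyond the scatter) and a 2.1-fold lower number from compound 2 to compound 3 (0.33 log units; beyond the scatter), while a 4.4-fold lower number from compound 1 to compound 3 (0.65 log units; beyond the scatter). Compound 4 `CN1CCN(c2cccc3c2C[C@H](CN(C)[C@H]2CCCc4cccnc42)N(C)C3)CC1` differs from compound 2 in one place: methyl in place of hydrogen on an amine nitrogen in a ring. Going by the values given here, none of the measured steps touches that ring amine nitrogen; the only methyl-for-hydrogen step, a 2.1-fold lower number from compound 2 to compound 3 (0.33 log units; beyond the scatter), sits on a saturated chain carbon bound to an amine nitrogen in a ring, and the other two steps exchange whole groups on the aromatic carbon. Among the compounds with values here, with no step bearing directly on this change, compound 4 is expected to shift little, a 1.0-fold higher number from compound 2 to compound 4 (0.01 log units; within the scatter). Compound 4 is therefore estimated at 30 nM, within a range of 10 nM to 90 nM.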

Compound 4, half-maximal inhibitory concentration: 171 nM
For compound 4 the middle estimate is 5.7-fold (0.76 log units) below the measured one, outside the stated range (above it).
By their numbers in this assay, from the lowest: compound 3; then compound 2; then compound 1; then compound 4.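

In this assay, methyl in place of hydrogen on this amine nitrogen gives a 5.8-fold higher number from compound 2 to compound 4 (0.76 log units; beyond the scatter), so the ring nitrogen, next to the ring atom that bears a large group, responds to a single added carbon. The change runs opposite to the other methyl-for-hydrogen step, a 2.1-fold lower number from compound 2 to compound 3 (0.33 log units; beyond the scatter), which sits on a saturated chain carbon. Nothing available accounts for this rise. Still open, as far as these compounds go, is whether ethyl or acetyl on this nitrogen behaves like methyl, and whether methyl there has the same effect alongside the 4-ethylpiperazin-1-yl group of compound 3.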